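Swapping a Hydroxy for a Methylsulfanyl Side Chain

The source may hold more compounds than are shown below. What is called first, only, known or untested is meant among the compounds shown, and "the series" means these compounds.

Compound 1 `N[C@@H](C(=O)NCc1ccccc1)C1CCCCC1`: 28 mg/kg
Compound 2 `N[C@H](CCO)C(=O)NCc1ccccc1`: > 160 mg/kg (a limit of the assay, not a number)

In a functional assay on the whole organism (strain NMRI) with Mus musculus as the target, in the maximal electroshock model, with a stated time of 30 min (on this read-out higher numbers stand for an effect only at larger amounts of compound and lower numbers for an effect already at smaller amounts), compound 1 gives 28 mg/kg. For compound 2 the result > 160 mg/kg is a limit of this assay rather than a number (the limit of > 160 mg/kg in this assay, at which 1 of the 2 values shown sits). Compound 2 thus sits at the limit, the weaker end of the two shown. For the measured compounds named here, the only measured step is an at least 5.7-fold higher number from compound 1 to compound 2 (0.75 log units; beyond the scatter). Compound 3 `CSCC[C@@H](N)C(=O)NCc1ccccc1` differs from compound 2 by methylsulfanyl in place of hydroxy on a saturated chain carbon, three bonds along the chain from an amine nitrogen and a carbonyl carbon. Because an at least 5.7-fold higher number from compound 1 to compound 2 (0.75 log units; beyond the scatter) rose when the hydroxyethyl entered, removing that hydroxy is expected to bring the number down, an estimated at least 2.6-fold lower number from compound 2 to compound 3 (0.42 log units; beyond the scatter). Compound 3 is expected at 60 mg/kg, within 20 mg/kg to 200 mg/kg.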

Compound 3, dose for half-maximal effect: 75 mg/kg
The estimate for compound 3 lay 1.3-fold (0.10 log units) below the measured number; the measured number falls inside the stated range.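

In this assay methylsulfanyl in place of hydroxy gives an at least 2.1-fold lower number from compound 2 to compound 3 (0.32 log units; beyond the scatter) and so shows that this side chain responds to the group at its end, not only to the loss of cyclohexyl. Even so, 2-(methylsulfanyl)ethyl in place of cyclohexyl still leaves a 2.7-fold higher number from compound 1 to compound 3 (0.43 log units; beyond the scatter) and does not regain the level of the cyclohexyl compound. The first of these steps gives only a bound, as compound 2 sits at a limit: the limit of > 160 mg/kg in this assay, at which 1 of the 3 values shown sits.

The compounds shown leave open whether an amine or a carboxylic acid at the chain end would behave like hydroxy or like methylsulfanyl. They also leave open whether a plain ethyl or a longer chain would match methylsulfanyl or come closer to cyclohexyl.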